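Side-chain replacement on a shared amide core: compound 4

This account rests on a few compounds, and the source may have more. Where it says the series, first, only, none or still open, it means among the compounds named here.

Measured compounds, read in an assay on COS-7 cells for displacement of a labelled ligand from 5-hydroxytryptamine receptor 4 (Homo sapiens), read by scintillation counting, with a stated time of 30 min; a higher number here means a weaker inhibitor, a lower number a stronger inhibitor:
compound 1 `CCCC(=O)N1CCC(CN2CC[C@H](NC(=O)c3cc(Cl)c(N)cc3OC)[C@H](OC)C2)CC1` gives 178 nM
compound 2 `COc1cc(N)c(Cl)cc1C(=O)N[C@H]1CCN(CCCn2cncn2)C[C@H]1OC` gives 1270 nM
compound 3 `CCC(=O)N1CCC(CCN2CC[C@H](NC(=O)c3cc(Cl)c(N)cc3OC)[C@H](OC)C2)CC1` gives 805 nM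

Compound 3 stands second highest of the three numbers in this assay; its nearest neighbour is compound 2, a gap within the scatter, and compound 1 sits furthest away with the lowest number. The two steps away from compound 1 are both beyond the scatter: a 7.1-fold higher number from compound 1 to compound 2 (0.85 log units; beyond the scatter) and a 4.5-fold higher number from compound 1 to compound 3 (0.66 log units; beyond the scatter). Between the other two, a 1.6-fold lower number from compound 2 to compound 3 (0.20 log units; within the scatter), which is within the scatter.

Compound 4 `COc1cc(N)c(Cl)cc1C(=O)N[C@H]1CCN(CCCn2cccc2)C[C@H]1OC` differs from compound 3 by (1H-pyrrol-1-yl)methyl in place of 1-propanoylpiperidin-4-yl on a saturated chain carbon, two bonds along the chain from an amine nitrogen in a ring. For the measured compounds named here, the step that bears on this is the one between compound 2 and compound 3, where a five-membered aromatic ring on a methylene at the same place was exchanged for the propanoylpiperidinyl group, and that step stayed within the scatter. Compound 4 returns to a five-membered aromatic ring at this place, so the expected step of a 1.5-fold higher number from compound 3 to compound 4 (0.17 log units; within the scatter) is small, if anything towards a slightly higher number. Compound 4 is therefore estimated at 1200 nM, with a range of 400 nM to 3500 nM.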

Compound 4, half-maximal inhibitory concentration: 648 nM
Beside the measured number, compound 4's estimate is 1.9-fold (0.27 log units) above it; low and high end bracket the measured number.
By their numbers in this assay, from the lowest: compound 1; then compounds 4, 3 and 2 (each within the scatter of the next).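

Working in this assay, the exchange of the 1-propanoylpiperidin-4-yl group, with its 10 heavy atoms and carbonyl, for the 6 heavy atoms of (1H-pyrrol-1-yl)methyl gives a 1.2-fold lower number from compound 3 to compound 4 (0.09 log units; within the scatter) and so does not separate these two groups at this place. Exchanging 1H-1,2,4-triazol-1-yl for 1H-pyrrol-1-yl on the same chain gives a 2.0-fold lower number from compound 2 to compound 4 (0.29 log units; within the scatter) and also leaves the two aromatic rings unseparated. For the compounds shown here, the gap to the lowest number persists, with a 3.6-fold higher number from compound 1 to compound 4 (0.56 log units; beyond the scatter) at this stage, so compound 1 remains the only compound set apart from the others.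

Open, going by these compounds, is whether an amine or a carboxylic acid at the end of this chain, or a longer chain, would shift the number, and whether chain length or the butanoyl group sets compound 1 apart. No measurement shown here explains any of these steps.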